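Chloro added to the urea aryl of compound 3

The compounds below may be only part of what the source reports. "The series", "measured", "known", "first", "only" and "open" are said of these compounds alone.

Compound 3 `COc1cc(-c2nn(-c3cccc(NC(=O)Nc4cccc(C(F)(F)F)c4)c3)cc2-c2ccncc2)ccc1Cl` carries the methoxy-chlorophenyl and pyridyl on the shared core with a diaryl urea on the pendant phenyl. In a functional assay on SF-295 cells (Homo sapiens) for inhibition, read by sulforhodamine B assay, with a stated time of 48 h (on this read-out higher numbers stand for lower toxicity in this test and lower numbers for higher toxicity in this test), compound 3 gives 3200 nM, the lowest of the two numbers given. Compound 1 `O=C(Nc1cccc(-n2cc(-c3ccncc3)c(-c3ccc(Cl)c(O)c3)n2)c1)Nc1cccc(C(F)(F)F)c1`, with hydroxyl in place of methoxy, gives 29200 nM; the step of a 9.1-fold lower number from compound 1 to compound 3 (0.96 log units; beyond the scatter). Compound 2 `COc1cc(-c2nn(-c3cccc(NC(=O)c4cccc(C(F)(F)F)c4)c3)cc2-c2ccncc2)ccc1Cl`, the amide counterpart, reaches only the limit > 50000 nM in this assay, as stated by the limit of > 50000 nM in this assay, at which 1 of the 3 values shown sits. The step of an at least 15-fold lower number from compound 2 to compound 3 (1.19 log units; beyond the scatter).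

Compound 4 `COc1cc(-c2nn(-c3cccc(NC(=O)Nc4ccc(Cl)c(C(F)(F)F)c4)c3)cc2-c2ccncc2)ccc1Cl` differs from compound 3 by chloro in place of hydrogen on an aromatic carbon. No measured step touches this position; the two steps shown concern the methoxy and the urea linker, both remote from this ring. Compound 3 is taken as the anchor, and the step is expected to be small, in either direction, and most likely within the scatter, written as a 1.8-fold lower number from compound 3 to compound 4 (0.25 log units; within the scatter). The expected value for compound 4 in this assay is 1800 nM, with a range from 450 nM to 8000 nM.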

Compound 4, concentration lethal to 50% of the cells: 14900 nM
Beside the measured number, compound 4's estimate is 8.3-fold (0.92 log units) below it; the measured number lies above the stated range.
By their numbers in this assay, from the lowest: compound 3; then compounds 4 and 1 (each within the scatter of the next). At a limit, above all of these: compound 2.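

The ring carrying the trifluoromethyl group responds to substitution: in this assay, chloro para to a large group and ortho to the trifluoromethyl group gives a 4.7-fold higher number from compound 3 to compound 4 (0.67 log units; beyond the scatter), a shift towards lower toxicity in this test. With the 4-chloro-3-(trifluoromethyl)phenyl group on the urea, the separation from the amide compound persists as an at least 3.3-fold lower number from compound 2 to compound 4 (0.52 log units; beyond the scatter). Compound 2 stands at a limit of the assay, not at a number: the limit of > 50000 nM in this assay, at which 1 of the 4 values shown sits.

From the compounds shown here alone, whether this shift belongs to chloro alone remains open, and a fluoro, methyl or amine at the same carbon would address it. Also open, going by these compounds, is whether the same chloro change carries over to the hydroxyl-bearing compound 1.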